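Sulfonamide Aryl Substituent Swap in a Kinase Inhibitor Series

A few compounds are considered here, and "the series" means these few. Any claim that something is new, unique, unknown or untested is made for them only; others in the source may bear on it.

compound 1 `O=C(COc1ccc2c(=O)ccoc2c1)Nc1cccc(NC(=O)c2ccccc2)c1`: 16 nM
compound 2 `N#Cc1ccc(C(=O)Nc2cccc(NC(=O)COc3ccc4c(=O)ccoc4c3)c2)cc1`: 15 nM
compound 3 `CN(C)c1ccc(S(=O)(=O)Nc2cccc(NC(=O)COc3ccc4c(=O)ccoc4c3)c2)cc1`: 263 nM

In an assay on isolated protein for inhibition of Rho-associated protein kinase 2 (Homo sapiens), read by scintillation counting, radiometric assay and 33P incorporation, with a stated time of 40 min, in the presence of a further agent that is not named here (a lower number here means a stronger inhibitor, a higher number a weaker inhibitor), compound 3 gives 263 nM, the highest of the three numbers; compound 1 and compound 2 both give far lower numbers, each gap lying beyond the scatter. Compound 4 `O=C(COc1ccc2c(=O)ccoc2c1)Nc1cccc(NS(=O)(=O)c2ccc(C(F)(F)F)cc2)c1` has not yet been measured. It differs from compound 3 by trifluoromethyl in place of dimethylamino on an aromatic carbon. For the measured compounds named here, only one measured step bears on this change: in the amide-linked pair, a 1.1-fold lower number from compound 1 to compound 2 (0.03 log units; within the scatter), so swapping the group on the terminal phenyl ring there left the number essentially unchanged. Going by the values given here, no measured step shows such a swap on a sulfonamide-linked compound. Compound 4 is therefore expected to stay close to compound 3, the expected step being a 1.3-fold lower number from compound 3 to compound 4 (0.12 log units; within the scatter). Compound 4 is estimated at 200 nM, within a range of 70 nM to 600 nM.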

Compound 4, half-maximal inhibitory concentration: 6890 nM
Beside the measured number, compound 4's estimate is 34-fold (1.54 log units) below it; the measured number lies above the stated range.
By their numbers in this assay, from the lowest: compounds 2 and 1 (each within the scatter of the next); then compound 3; then compound 4.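

Replacing dimethylamino with trifluoromethyl on the terminal phenyl ring of this sulfonamide-linked series gives a 26-fold higher number from compound 3 to compound 4 (1.42 log units; beyond the scatter) in this assay, so the number here responds strongly to the group at this position. The amide-linked pair, with a different swap, had shown only a 1.1-fold lower number from compound 1 to compound 2 (0.03 log units; within the scatter), and that flat response does not carry over to this sulfonamide-linked pair. Nothing available accounts for the size of this step. Still open, going by these compounds, is whether the rise follows from losing dimethylamino or from gaining trifluoromethyl. On these data alone, how a methoxy group, a primary amine or a carboxylic acid would read at this position also remains unknown.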